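This account rests on a few compounds, and the source may have more. Where it says the series, first, only, none or still open, it means among the compounds named here.

Compound 1 (`O=C(NCc1ccc(S(=O)(=O)c2cccc(C(F)(F)F)c2)cc1)c1cc2cnccc2[nH]1`) and compound 2 (`O=C(NCc1ccc(S(=O)(=O)c2cccc(C(F)(F)F)c2)cc1)c1cnc2nccn2c1`) differ only in the group on the carbonyl carbon. In a functional assay on A2780 cells (Homo sapiens) for inhibition, read by sulforhodamine B assay, with a stated time of 72 h (on this read-out higher numbers stand for weaker inhibition and lower numbers for stronger inhibition), compound 1 gives 3 nM and compound 2 gives 2 nM. These two numbers lie within the scatter of each other, so compound 2 stands level with compound 1 at the potent end of this very small set.

Compound 3 (`O=C(NCc1ccc(S(=O)(=O)c2cccc(C(F)(F)F)c2)cc1)c1ccc2nccn2c1`) keeps everything in compound 2 except that group, and the change is a group of 9 heavy atoms (7 carbon, 2 nitrogen; one five-membered aromatic ring with 2 hetero atoms, one six-membered aromatic ring with 1 hetero atom) in place of a group of 9 heavy atoms (6 carbon, 3 nitrogen; one five-membered aromatic ring with 2 hetero atoms, one six-membered aromatic ring with 2 hetero atoms), on a carbonyl carbon. It sits in the same place, on a carbonyl carbon whose other neighbour is an amide-type nitrogen.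

Among the compounds with values here, only one measured step bears on this exchange: a 1.5-fold lower number from compound 1 to compound 2 (0.18 log units; within the scatter). That step also replaced one group on the carbonyl carbon with another of the same heavy-atom count, and it produced no change beyond the scatter. Within the data shown here, one step is thin evidence, and no measured compound carries the entering group itself. Even so, no shift beyond the scatter is expected in this assay.

The expected change is a 1.5-fold higher number from compound 2 to compound 3 (0.18 log units; within the scatter). Compound 3 is estimated at 3 nM, with an expected range from 1 nM to 10 nM.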

Compound 3, half-maximal inhibitory concentration: 2 nM
Compound 3: middle estimate off by 1.5-fold (0.18 log units), on the high side; the measured number falls inside the stated range.
By their numbers in this assay, from the lowest: compounds 2, 3 and 1 (each within the scatter of the next).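

The exchange of the group with 3 nitrogen atoms for the one with 2 on the carbonyl carbon gives no change at the digits printed from compound 2 to compound 3 (within the scatter) in this assay, even though the hydrogen-bond acceptors in the group go from 3 to 2 while the hydrogen-bond donors stay at 0. Set against the group in compound 1, the same entering group gives a 1.5-fold lower number from compound 1 to compound 3 (0.18 log units; within the scatter), so three different groups of 9 heavy atoms, each with one five-membered and one six-membered aromatic ring, now stand on this carbonyl carbon with no step among them beyond the scatter, and no compound shown goes against this. Nothing shown explains why these exchanges leave the number in place.

All three groups have the same heavy-atom count and the same pair of aromatic rings, so the compounds shown leave open whether a plain phenyl or pyridine ring, with one aromatic ring alone, would hold up equally on this carbonyl carbon. They also leave open what an amine or a carboxylic acid carried on the entering group would do in this assay.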